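A few compounds are considered here, and "the series" means these few. Any claim that something is new, unique, unknown or untested is made for them only; others in the source may bear on it.

Measured so far:
compound 1 `O=C(c1ccc(C(F)(F)F)cc1)N1CCC(NS(=O)(=O)c2cc(S(=O)(=O)c3ccccc3)ccc2C(F)(F)F)CC1` — 970 nM
compound 2 `O=C(c1cccnc1)N1CCC(NS(=O)(=O)c2cc(S(=O)(=O)c3ccccc3)ccc2C(F)(F)F)CC1` — 120 nM

In an assay on U2OS cells for inhibition of secreted frizzled-related protein 1 (Homo sapiens), read by a luciferase reporter, with a stated time of 18 h (a higher number here means that more compound is needed for the effect, a lower number that less compound is needed), compound 2 gives the lowest of the two numbers; its nearest neighbour is compound 1, separated by an 8.1-fold lower number from compound 1 to compound 2 (0.91 log units; beyond the scatter). Compound 3 `N#Cc1cccc(S(=O)(=O)N2CCC(NS(=O)(=O)c3cc(S(=O)(=O)c4ccccc4)ccc3C(F)(F)F)CC2)c1` differs from compound 2 by (3-cyanophenyl)sulfonyl in place of (pyridin-3-yl)carbonyl on an amine nitrogen in a ring. Within the data shown here, the one measured step bears only loosely on this: it changed the ring on the carbonyl, whereas here the carbonyl itself leaves. A step of similar size is plausible in either direction, though a higher number is expected. Compound 3 is estimated at 300 nM, range 80 nM to 1200 nM. That estimate implies a 2.5-fold higher number from compound 2 to compound 3 (0.40 log units; beyond the scatter).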

Compound 3, half-maximal effective concentration: 170 nM
Beside the measured number, compound 3's estimate is 1.8-fold (0.25 log units) above it; the measured number falls inside the stated range.
By their numbers in this assay, from the lowest: compounds 2 and 3 (each within the scatter of the next); then compound 1.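

On the amine nitrogen in the six-membered non-aromatic ring, a sulfonyl link with a 3-cyanophenyl group reads much like a carbonyl link with a pyridin-3-yl group in this assay: the change gives a 1.4-fold higher number from compound 2 to compound 3 (0.15 log units; within the scatter). Against the 4-(trifluoromethyl)phenyl amide, the same kind of exchange gives a 5.7-fold lower number from compound 1 to compound 3 (0.76 log units; beyond the scatter), so a ring nitrogen is not needed to stay clear of compound 1. No measurement at hand accounts for either step.

As far as these compounds go, the link and the aromatic ring change together in both steps, so their separate contributions stay open. Also open, from the compounds shown here alone, is how a small acetyl group or an alkyl chain would read on this nitrogen.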